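Chlorophenylsulfonamide series: moving the chlorine on compound 1

The compounds below may be only part of what the source reports. "The series", "measured", "known", "first", "only" and "open" are said of these compounds alone.

Measured so far:
compound 1 `COc1ccccc1C(=O)NCc1ccc(CNS(=O)(=O)c2cccc(Cl)c2)cc1` — 1000 nM
compound 2 `Cc1ccccc1C(=O)NCc1ccc(CNS(=O)(=O)c2cccc(Cl)c2)cc1` — 100 nM
compound 3 `O=C(NCc1ccc(CNS(=O)(=O)c2cccc(Cl)c2)cc1)c1cccnc1` — 100 nM

In an assay on MDA-MB-231 cells for displacement of a labelled ligand from C-X-C chemokine receptor type 4 (Homo sapiens), read by fluorescence and microscopy, with stated times of 10 min and 30 min (on this read-out higher numbers stand for an effect only at larger amounts of compound and lower numbers for an effect already at smaller amounts), compound 1 stands at the highest number of the three; the nearest, compound 2, lies a full step down, as does compound 3, with a 10-fold lower number from compound 1 to compound 2 (1.00 log units; beyond the scatter) and a 10-fold lower number from compound 1 to compound 3 (1.00 log units; beyond the scatter) both beyond the scatter, while no change at the digits printed from compound 2 to compound 3 (within the scatter) is within it.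

Compound 4 `COc1ccccc1C(=O)NCc1ccc(CNS(=O)(=O)c2ccccc2Cl)cc1` differs from compound 1 in 2-chlorophenyl in place of 3-chlorophenyl on a sulfonyl sulfur. Among the compounds with values here, all three measured steps concern the amide side of the shared core; none touches the sulfonyl side, so no measured step bears on this change. The expectation is therefore a step of no change at the digits printed from compound 1 to compound 4 (within the scatter), none beyond the scatter. For compound 4 the estimate is 1000 nM, expected between 300 nM and 3000 nM.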

Compound 4, effective concentration (reported as EC, without a stated level of effect): 100 nM
Compound 4: middle estimate off by 10-fold (1.00 log units), on the high side; measured number below the stated range.
By their numbers in this assay, from the lowest: compounds 2, 3 and 4 (each within the scatter of the next); then compound 1.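

Within the data shown here, the sulfonyl side, untouched by the earlier steps, now proves able to shift the number: 2-chlorophenyl in place of 3-chlorophenyl on the sulfonyl sulfur, with the same atoms joined differently, gives a 10-fold lower number from compound 1 to compound 4 (1.00 log units; beyond the scatter) on the unchanged amide side. The high number of compound 1, 1000 nM, therefore does not follow from its 2-methoxyphenyl amide alone. No measurement at hand bears on the reason for this step.

Going by these compounds, whether 2-chlorophenyl gives a similar step on the amides of compound 2 and compound 3 stays open. So does how a plain phenyl or a 4-chlorophenyl on the sulfonyl sulfur would read.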